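The source may report more compounds than this note shows. Statements on the series, on what has been measured and on what is new or still open speak of the compounds shown alone.

Compound 1 `COc1ccc2cc(C(C)c3nnc4n3N=C(c3ccc(Cl)cc3Cl)CS4)ccc2c1` stands at the highest of the three numbers in a functional assay on Huh-7 cells (Homo sapiens) for inhibition, read by sulforhodamine B assay, with a stated time of 72 h (on this read-out higher numbers stand for weaker inhibition and lower numbers for stronger inhibition), giving 10700 nM. Compound 2 `CC(c1ccc(-c2ccccc2)c(F)c1)c1nnc2n1N=C(c1ccc(C(F)(F)F)cc1)CS2` gives 9400 nM in this assay and compound 3 `CC(c1ccc(-c2ccccc2)c(F)c1)c1nnc2n1N=C(c1ccc(Br)cc1)CS2` gives 5000 nM; compound 2 lies within the scatter of compound 1, while compound 3 lies beyond it. Compound 4 `COc1ccc2cc(C(C)c3nnc4n3N=C(c3ccc(F)cc3)CS4)ccc2c1` keeps the core of compound 1 with one change: 4-fluorophenyl in place of 2,4-dichlorophenyl on a carbon with a double bond to nitrogen. Among the measured compounds shown here, the only measured step that bears on swapping the ring on the carbon with a double bond to nitrogen is a 1.9-fold lower number from compound 2 to compound 3 (0.27 log units; within the scatter), which stayed within the scatter. On that basis compound 4 is expected to show a 1.1-fold lower number from compound 1 to compound 4 (0.03 log units; within the scatter), nothing beyond the scatter. Compound 4 is therefore estimated at 10000 nM, with a range of 4000 nM to 25000 nM.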

Compound 4, half-maximal inhibitory concentration: 7000 nM
Compound 4: the middle estimate sits 1.4-fold (0.15 log units) above what was measured; measured number inside the range.
By their numbers in this assay, from the lowest: compounds 3, 4, 2 and 1 (each within the scatter of the next, the first and the last beyond it).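

On the core of compound 1, in this assay, 4-fluorophenyl in place of 2,4-dichlorophenyl gives a 1.5-fold lower number from compound 1 to compound 4 (0.18 log units; within the scatter) and so leaves the two compounds alike. The earlier step covered only a swap of trifluoromethyl for bromo on a para-free reading of the core of compound 2, whereas this one removes both chlorines and adds fluorine on a different core, and still nothing moves beyond the scatter. No measurement offers an explanation for this result.

As far as these compounds go, whether an amine or a carboxylic acid on this ring would separate from these values stays open. So does whether 4-fluorophenyl reads alike on the core of compound 2.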